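The compounds below may be only part of what the source reports. "The series", "measured", "known", "first", "only" and "open" are said of these compounds alone.

Three compounds with the same core, differing only in the group on an amine nitrogen in a ring, have been measured in a functional assay on HL-60 cells (Homo sapiens) for inhibition, read by MTT assay, with a stated time of 72 h; on this read-out lower numbers stand for stronger inhibition and higher numbers for weaker inhibition. In this test, compound 1 `Cc1nc(-c2ccccc2)c(C(=O)N2CCN(c3cccc(Cl)c3)CC2)o1` gives 39.2 nM, compound 2 `Cc1ccc(C)c(N2CCN(C(=O)c3oc(C)nc3-c3ccccc3)CC2)c1` gives 31.3 nM, and compound 3 `Cc1nc(-c2ccccc2)c(C(=O)N2CCN(c3ccccc3Cl)CC2)o1` gives 124 nM. Compound 3 therefore has the highest number of the three and is the weakest inhibitor so far. The steps show this: there is a 3.2-fold higher number from compound 1 to compound 3 (0.50 log units; beyond the scatter), and there is a 4.0-fold higher number from compound 2 to compound 3 (0.60 log units; beyond the scatter). By contrast, there is a 1.3-fold lower number from compound 1 to compound 2 (0.10 log units; within the scatter), so the other two compounds cannot be told apart.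

The next compound, compound 4 `Cc1nc(-c2ccccc2)c(C(=O)N2CCN(c3ccc(F)cc3)CC2)o1`, has 4-fluorophenyl in place of 2-chlorophenyl on an amine nitrogen in a ring. Going by the values given here, no measured compound carries this new group, so no measured step shows this exact exchange. The closest evidence is the two steps that end at compound 3, and both suggest that replacing its 2-chlorophenyl could lower the number. With so few compounds, only part of that gap is assumed to be recovered. In this assay, the expected change is a 1.8-fold lower number from compound 3 to compound 4 (0.25 log units; within the scatter). The estimate for compound 4 is 70 nM, with an expected range of 25 nM to 190 nM.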

Compound 4, half-maximal inhibitory concentration: > 1000 nM
Compound 4: only a limit was reported (the forecaster's own chance of this, stated with the estimate: 2%); middle value at least 14-fold (1.15 log units) from the limit.
By their numbers in this assay, from the lowest: compounds 2 and 1 (each within the scatter of the next); then compound 3. At a limit, above all of these: compound 4.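

On these data alone, the reading for compound 4 is a limit and not a number, so the true size of its value stays unknown: the limit of > 1000 nM in this assay, at which 1 of the 4 values shown sits. Even so, this assay shows that the group on this amine nitrogen can matter far more than the earlier compounds revealed: there is an at least 8.0-fold higher number from compound 3 to compound 4 (0.90 log units; beyond the scatter), there is an at least 31-fold higher number from compound 2 to compound 4 (1.50 log units; beyond the scatter), and there is an at least 25-fold higher number from compound 1 to compound 4 (1.40 log units; beyond the scatter). Until now every aryl group at this position gave a measured value, whereas this exchange keeps a six-membered aromatic ring of carbon only and adds no hydrogen-bond donor or acceptor, yet the reading reaches the limit of the assay.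

Compound 4 differs from compound 3 in both the halogen and where it sits on the phenyl ring, and the compounds shown cannot separate these two changes, as neither 4-chlorophenyl nor 3-fluorophenyl stands among them. They also leave open how a non-aromatic group such as cyclohexyl, or a phenyl ring carrying an amine or a carboxylic acid, would behave on this nitrogen.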